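The source may report more compounds than this note shows. Statements on the series, on what has been measured and on what is new or still open speak of the compounds shown alone.

In a functional assay on PC-3 cells (Homo sapiens) for cytotoxicity, read by colorimetric assay and MTT assay (on this read-out lower numbers stand for stronger inhibition and higher numbers for weaker inhibition), three compounds have been measured so far. Compound 1 `COc1ccc2cc(-c3ccccc3)c(O)nc2c1` gives 10000 nM, compound 2 `COc1cc(OC)c2cc(-c3ccccc3)c(O)nc2c1` gives 10000 nM and compound 3 `COc1ccc(-c2cc3c(OC)ccc(OC)c3nc2O)cc1` gives 10000 nM, so compound 2 stands level with both of the others. Compound 4 `COc1cc(OC)c2cc(-c3ccc(OCc4ccccc4)cc3)c(O)nc2c1` departs from compound 2 by a single change, benzyloxy in place of hydrogen on an aromatic carbon, para to a large group. For the measured compounds named here, the one measured step that bears on this is no change at the digits printed from compound 1 to compound 2 (within the scatter), which also swaps hydrogen on an aromatic carbon, here for methoxy, and stays within the scatter. Compound 3 carries methoxy where compound 4 carries benzyloxy, and compound 3 shows the same 10000 nM. None of these compounds tests a group as large as benzyloxy, so the flat values give only weak guidance. Little movement is therefore expected, with any shift leaning towards stronger inhibition. The estimated change is a 1.3-fold lower number from compound 2 to compound 4 (0.10 log units; within the scatter). For compound 4 the estimate is 8000 nM, with an expected range of 2500 nM to 15000 nM.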

Compound 4, half-maximal inhibitory concentration: 10000 nM
For compound 4 the middle estimate is 1.3-fold (0.10 log units) below the measured one; the range from low to high includes it.
By their numbers in this assay, from the lowest: compounds 1, 2, 3 and 4 (each within the scatter of the next).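

In this assay, putting benzyloxy in place of hydrogen gives no change at the digits printed from compound 2 to compound 4 (within the scatter). The step is the first shown at this aromatic carbon, para to a large group, and it shows that a group of 8 heavy atoms with a six-membered aromatic ring of carbon only can stand there with no change at the digits printed. Nothing shown here accounts for this flat result.

Since all four compounds are level with one another, the series does not show whether any group at this position can move the number in either direction. As far as these compounds go, an amine, a carboxylic acid or a longer chain ending in a hydroxyl group on this aromatic carbon remains open, as does replacing the hydroxyl group on the shared core with an amine.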